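Cyclopropyl for 4-fluorophenyl on compound 2

A few compounds are considered here, and "the series" means these few. Any claim that something is new, unique, unknown or untested is made for them only; others in the source may bear on it.

Three compounds measured in a functional assay on the whole organism with Mus musculus as the target (on this read-out higher numbers stand for an effect only at larger amounts of compound and lower numbers for an effect already at smaller amounts), so far:

compound 1 `C[C@@H](NCc1ccc(SCc2ccccc2)cc1)C(N)=O` gives 24.8 mg/kg
compound 2 `C[C@@H](NCc1ccc(OCc2ccc(F)cc2)cc1)C(N)=O` gives 132 mg/kg
compound 3 `CNC(=O)[C@@H](CO)NCc1ccc(OCc2cccc(OC)c2)cc1` gives 109 mg/kg

In this assay compound 2 at 132 mg/kg stands level with compound 3 within the scatter, while compound 1 lies beyond the scatter on the side of smaller doses. Compound 4 `C[C@@H](NCc1ccc(OCC2CC2)cc1)C(N)=O` has not yet been measured. It carries cyclopropyl in place of 4-fluorophenyl on a saturated chain carbon bound to an oxygen on an aromatic ring. For the measured compounds named here, no measured pair shows this change alone, so the evidence is thin. Compound 1 at 24.8 mg/kg shows that much lower numbers occur among these compounds, but it differs from compound 2 in more than one place. Only a small move toward a lower number, within the scatter, is therefore expected in this assay for this change. The estimate is a 1.6-fold lower number from compound 2 to compound 4 (0.19 log units; within the scatter) and it remains an expectation. The expected value for compound 4 is 85 mg/kg (expected range 30 mg/kg to 220 mg/kg).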

Compound 4, dose for half-maximal effect: 124 mg/kg
For compound 4 the middle estimate is 1.5-fold (0.16 log units) below the measured one; low and high end bracket the measured number.
By their numbers in this assay, from the lowest: compound 1; then compounds 3, 4 and 2 (each within the scatter of the next).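

In this assay, for the compounds shown here, the first comparison at this place, on a saturated chain carbon bound to an oxygen on an aromatic ring, gives a 1.1-fold lower number from compound 2 to compound 4 (0.03 log units; within the scatter) for cyclopropyl in place of 4-fluorophenyl. The two compounds therefore stand level, although a three-membered non-aromatic ring of 3 heavy atoms has replaced a six-membered aromatic ring of 7 heavy atoms, so this read-out does not separate these two groups here. No measurement shown gives a reason for this result.

Going by these compounds, whether an amine, a carboxylic acid or a longer chain at this place would stay level with these two groups remains open. Also open, on these data alone, is whether the same replacement would give a similar step on a compound that differs elsewhere in the shared core.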